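Bromo to Fluoro on a Shared Core: Expecting No Shift

The source may hold more compounds than are shown below. What is called first, only, known or untested is meant among the compounds shown, and "the series" means these compounds.

Measured so far in a functional assay on MV4-11 cells (Homo sapiens) for cytotoxicity, read by colorimetric assay and MTT assay, with a stated time of 3 days, tested at 1 uM; on this read-out lower numbers stand for a stronger effect and higher numbers for a weaker effect at the one concentration tested:
compound 1 `O=C1COc2ccc(-c3[nH]c(-c4ccc(C(F)(F)F)cc4)nc3-c3ccccc3)cc2N1` gives 111%
compound 2 `COc1ccc(-c2nc(-c3ccccc3)c(-c3ccc4c(c3)NC(=O)CO4)[nH]2)cc1` gives 108%
compound 3 `O=C1COc2ccc(-c3nn(-c4ccc(Br)cc4)cc3-c3ccccc3)cc2N1` gives 108%

Compound 3 stands level with compound 2 at the digits shown, and its gap to compound 1 lies within the scatter, so the three numbers sit together and none of the compounds moves the read-out much at the single concentration tested. Compound 4 `O=C1COc2ccc(-c3nn(-c4ccc(F)cc4)cc3-c3ccccc3)cc2N1` differs from compound 3 in one place: fluoro in place of bromo on an aromatic carbon. Among the measured compounds shown here, only one measured step exists, a number 3 percentage points lower from compound 1 to compound 2 (within the scatter), and it exchanges a different group, also on an aromatic carbon; it stays within the scatter. For the measured compounds named here, no measured step exchanges bromo for fluoro. The expectation for compound 4 therefore rests on the flatness of the three numbers and on that one step: no movement beyond the scatter is expected, the estimated step being a number 1 percentage points lower from compound 3 to compound 4 (within the scatter). Compound 4 is thus expected to give 107%, with a range from 95% to 120%.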

Compound 4, a percentage reported as activity, at one concentration (the size of the read-out at that concentration, not a potency): 107%
For compound 4 middle estimate and measured number coincide at the digits printed; low and high end bracket the measured number.
By their numbers in this assay, from the lowest: compounds 4, 2, 3 and 1 (each within the scatter of the next).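

Going from 4-bromophenyl to 4-fluorophenyl on the shared core gives a number 1 percentage points lower from compound 3 to compound 4 (within the scatter) in this assay. Among the compounds shown here, this is the first direct reading of this exchange, and it shows that on this aromatic carbon, para to a large group, bromo and fluoro cannot be told apart by this read-out at the single concentration tested. No measurement available here explains this result or links it to any property of either group.

For the compounds shown here, still open is whether this position can move the read-out at all, as the only two groups compared on it are both single halogen atoms. An amine or a carboxylic acid on the same aromatic carbon would show whether a very different group leaves the number just as unchanged.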